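A few compounds are considered here, and "the series" means these few. Any claim that something is new, unique, unknown or untested is made for them only; others in the source may bear on it.

Working notes on the series. The shared core carries a varied aryl group: compound 1 `CCC1=C(O)c2c(oc(-c3ccc(C(F)(F)F)cc3)cc2=O)C(CC)(CC)C1=O`, compound 2 `CCC1=C(O)c2c(oc(-c3ccc(F)cc3)cc2=O)C(CC)(CC)C1=O` and compound 3 `CCC1=C(O)c2c(oc(-c3ccc(COC)cc3)cc2=O)C(CC)(CC)C1=O`. In a functional assay on KB cells (Homo sapiens) for antiproliferative activity, read by sulforhodamine B assay, with a stated time of 3 days (on this read-out higher numbers stand for an effect only at larger amounts of compound and lower numbers for an effect already at smaller amounts), compound 1 gives 35.7 uM, and compound 2 gives 33 uM. For compound 3 only a limit is recorded, > 52.4 uM. Compound 3 thus stands at the limit of > 52.4 uM in this assay, at which 1 of the 3 values shown sits, and has no number of its own. The next change, to compound 4 `CCC1=C(O)c2c(oc(-c3cc(C)c(C)cc3C)cc2=O)C(CC)(CC)C1=O`, is 2,4,5-trimethylphenyl in place of 4-(methoxymethyl)phenyl on an aromatic carbon. The measured steps at this position are all small: a 1.1-fold lower number from compound 1 to compound 2 (0.03 log units; within the scatter), an at least 1.4-fold higher number from compound 1 to compound 3 (0.16 log units; that floor lies within the scatter) and an at least 1.5-fold higher number from compound 2 to compound 3 (0.20 log units; that floor lies within the scatter). No step beyond the scatter is therefore expected in this assay, in either direction. Compound 4 is estimated at 45 uM, within 15 uM to 130 uM. The expected step is an at least 1.1-fold lower number from compound 3 to compound 4 (0.06 log units; that floor lies within the scatter), possibly again ending at a limit.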

Compound 4, concentration for half-maximal effect: 8.2 uM
For compound 4 the middle estimate is 5.5-fold (0.74 log units) above the measured one, and the stated range ends above it.
By their numbers in this assay, from the lowest: compound 4; then compounds 2 and 1 (each within the scatter of the next). At a limit, above all of these: compound 3.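

Going by these compounds alone, at this position the aryl group does shift the read-out in this assay, with the first steps here beyond the scatter: an at least 6.3-fold lower number from compound 3 to compound 4 (0.80 log units; beyond the scatter) and a 4.0-fold lower number from compound 2 to compound 4 (0.60 log units; beyond the scatter). The earlier aryl groups gave no sign of this, and 2,4,5-trimethylphenyl now goes with a lower number than 4-fluorophenyl. Compound 3 is held at a limit, so its step is only a floor: the limit of > 52.4 uM in this assay, at which 1 of the 4 values shown sits.

It remains open which of the methyl groups carries the change, since a phenyl ring with a single methyl is not among the compounds shown. Also open, as far as these compounds go, is how an amine or a carboxylic acid on the aryl group would read.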